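From hydroxy to acetoxy at the assay limit

The compounds below may be only part of what the source reports. "The series", "measured", "known", "first", "only" and "open" are said of these compounds alone.

Compound 1 (`CO[C@@]12CC[C@H](O)[C@@](C)(CC[C@@H]3/C(=C\C=C\C(C)(C)O)COC(=O)[C@H]31)C2`) carries a free hydroxy group on the core it shares with compound 3. In a functional assay on WiDr cells (Homo sapiens) for cytotoxicity, with a stated time of 72 h (a lower number here means that less compound is needed, a higher number that more compound is needed for the effect), compound 1 gives > 20 ug/mL as its result, which is a limit of the assay and not a number. In this assay compound 2 (`C=C1C(=O)[C@H](OC(=O)c2ccccc2)/C=C(\C)CC[C@@H]2C([C@H](OC(C)=O)[C@@H](C=C(C)C)OC(C)=O)=CO[C@@H](OC(C)=O)[C@@H]12`) gives > 20 ug/mL as its result, again only a limit. Compound 1 therefore has no number of its own, and the two results shown sit together (the limit of > 20 ug/mL in this assay, at which 2 of the 2 values shown sit) at one ceiling.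

Compound 3 (`CO[C@@]12CC[C@H](OC(C)=O)[C@@](C)(CC[C@@H]3/C(=C\C=C\C(C)(C)O)COC(=O)[C@H]31)C2`) has not yet been measured. It differs from compound 1 by acetyl in place of hydrogen on an oxygen on a saturated carbon, a change from hydroxy to acetoxy. Among the measured compounds shown here, no measured pair shows what such a change does here. The expectation rests on compound 1 sitting at > 20 ug/mL as a limit. In this assay no shift beyond the usual scatter is expected, and the estimated step is a step that the limit leaves unreadable from compound 1 to compound 3 in size. For compound 3 the expected value is 25 ug/mL within an estimated range from 12 ug/mL to 40 ug/mL and a report of only a limit is the likeliest outcome.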

Compound 3, concentration for half-maximal effect: > 20 ug/mL
Compound 3 gave a limit, no number (the forecaster's own chance of this, stated with the estimate: 75%); the middle value is on the limit's open side.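

In this assay compound 3 gives > 20 ug/mL, which is a limit of the assay and not a number. Compound 1 also has only a limit, so no step can be read between compound 1 and compound 3: the limit of > 20 ug/mL in this assay, at which 3 of the 3 values shown sit. The compounds shown leave open whether, and how far, the change from hydroxy to acetoxy moves the result in this assay.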